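A few compounds are considered here, and "the series" means these few. Any claim that something is new, unique, unknown or untested is made for them only; others in the source may bear on it.

Compound 1 `CCN(CC)S(=O)(=O)c1ccc(S(=O)(=O)N2CCC[C@@H](C(=O)NC3CN(C(=O)OC(C)(C)C)C3)C2)cc1` is the starting point of this account. In a functional assay on MIA PaCa-2 cells (Homo sapiens) for inhibition, read by MTT assay, with a stated time of 3 days (a higher number here means a weaker inhibitor, a lower number a stronger inhibitor), compound 1 gives only a limit, > 10000 nM, and no number. Compound 2 `CCOC(=O)[C@@H]1CCCN(S(=O)(=O)c2ccc(S(=O)(=O)N(CC)C(C)C)cc2)C1` is the other measured member of the set. In this assay compound 2 likewise gives only a limit, > 10000 nM. Going by the values given here, the evidence at hand is therefore (the limit of > 10000 nM in this assay, at which 2 of the 2 values shown sit), and no measured step between the two compounds can be read from it. Compound 3 `CCN(CC)S(=O)(=O)c1ccc(S(=O)(=O)N2CCC[C@@H](C(=O)NC3CN(C(=O)NC(C)(C)C)C3)C2)cc1` is the unmeasured partner of compound 1; the change on the way to it is (tert-butyl)amino in place of tert-butoxy on a carbonyl carbon. Among the compounds with values here, with no measured step to lean on, the estimate rests on the limit alone. The step that this estimate means is a step that the limit leaves unreadable from compound 1 to compound 3, expected to be none beyond the usual scatter. Compound 3 is accordingly estimated at 15000 nM, with a range of 5000 nM to 50000 nM, and it is expected to be reported most probably as a limit once more.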

Compound 3, half-maximal inhibitory concentration: > 10000 nM
Compound 3: a limit, no number; the forecaster's own chance of this, stated with the estimate: 80%; the middle value lies beyond the limit too.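

Compound 3, like compound 1, gives only a limit in this assay, so no step can be read between compound 1 and compound 3. The compounds shown leave open how strongly any of them inhibits, and what the evidence offers is only this: the limit of > 10000 nM in this assay, at which 3 of the 3 values shown sit.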